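The compounds below may be only part of what the source reports. "The series", "measured", "known", "first", "only" and "open" are said of these compounds alone.

Values measured in an ADME assay on MDCK cells (Canis lupus familiaris) for cytotoxicity, read by MTT assay, with a stated time of 48 h; a lower number here means that less compound is tolerated, a higher number that more compound is tolerated:
- Compound 1 `COC(=O)[C@@H](NC(=O)CSc1nc(-c2ccccc2)cc(-c2ccc(C)cc2)c1C#N)C(C)C`: 210000 nM
- Compound 2 `Cc1ccc(-c2cc(-c3ccccc3)nc(SCC(=O)N[C@H](C(=O)O)C(C)C)c2C#N)cc1`: > 250000 nM

The value for compound 2 is a limit of the assay and not a number. Compound 2 stands at the limit of > 250000 nM in this assay, at which 1 of the 2 values shown sits. Compound 3 `COC(=O)C[C@H](NC(=O)[C@@H](NC(=O)CSc1nc(-c2ccccc2)cc(-c2ccc(C)cc2)c1C#N)C(C)C)C(=O)OC` has (1,2-bis(methoxycarbonyl)ethyl)amino in place of hydroxy on a carbonyl carbon. Among the measured compounds shown here, this is a much larger swap than the only measured step, an at least 1.1-fold higher number from compound 1 to compound 2 (0.07 log units; that floor lies within the scatter), so that step is just a loose guide. Still, it offers no sign of a large shift in this assay, and compound 1 at 210000 nM also shows very high tolerance. The estimated step is an at least 1.2-fold lower number from compound 2 to compound 3 (0.09 log units; that floor lies within the scatter), and none beyond the scatter is expected. For compound 3 the estimate is 200000 nM, with an expected range from 80000 nM to 320000 nM.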

Compound 3, half-maximal cytotoxic concentration: > 250000 nM
Compound 3 was reported as a limit; the forecaster's own chance of this, stated with the estimate: 40%; middle value at least 1.2-fold (0.09 log units) from the limit.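

In this assay compound 3 gives > 250000 nM, which is a limit of the assay and not a number. Among the compounds shown here, this carbonyl carbon therefore accepts the much larger (1,2-bis(methoxycarbonyl)ethyl)amino group with no sign of lower tolerance: the one readable step, an at least 1.1-fold higher number from compound 1 to compound 3 (0.07 log units; that floor lies within the scatter), stays within the scatter, while the step that joins the two limits cannot be read. Limits now make up most of the values shown: the limit of > 250000 nM in this assay, at which 2 of the 3 values shown sit.

From the compounds shown here alone, how far compound 2 and compound 3 each lie past the limit remains unknown, so any difference between them stays hidden. Going by these compounds, it also remains open whether a plain amino group or a longer carbon chain in place of the hydroxy on this carbonyl carbon would give a measurable value in this assay.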